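This account rests on a few compounds, and the source may have more. Where it says the series, first, only, none or still open, it means among the compounds named here.

Measured so far:
Compound 1 `CC(C)(C)OC(=O)N1CCN(C(=S)SCc2cn(Cc3ccc(Cl)c(Cl)c3)nn2)CC1` — > 128000 nM
Compound 2 `O=C(OCc1ccccc1)N1CCN(C(=S)SCc2cn(Cc3ccc(Cl)c(Cl)c3)nn2)CC1` — > 128000 nM
Compound 3 `CC(C)(C)OC(=O)N1CCN(C(=S)SCc2cn(Cc3ccccc3Cl)nn2)CC1` — 12500 nM

In a functional assay on PC-3 cells (Homo sapiens) for inhibition, read by MTT assay, with a stated time of 72 h (a higher number here means a weaker inhibitor, a lower number a stronger inhibitor), compound 1 gives > 128000 nM, which is a limit of the assay rather than a number. In this assay compound 2 likewise gives > 128000 nM, again a limit. Compound 3 is the only one of the three with a number: in this assay compound 3 gives 12500 nM. Swapping the benzyl substituent on the core, (2-chlorophenyl in place of 3,4-dichlorophenyl on a saturated chain carbon bound to an aromatic nitrogen), gave an at least 10-fold lower number from compound 1 to compound 3 (1.01 log units; beyond the scatter). The other change, (benzyl in place of tert-butyl on an oxygen next to a carbonyl group), made a step whose size cannot be read because the limit of > 128000 nM in this assay, at which 2 of the 3 values shown sit, hides both ends of it: a step that the two limits leave unreadable from compound 1 to compound 2.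

Compound 4 `O=C(OCc1ccccc1)N1CCN(C(=S)SCc2cn(Cc3ccccc3Cl)nn2)CC1` is not yet measured. It differs from compound 3 by benzyl in place of tert-butyl on an oxygen next to a carbonyl group, the same change that turned compound 1 into compound 2; the two cores differ as stated for (2-chlorophenyl in place of 3,4-dichlorophenyl on a saturated chain carbon bound to an aromatic nitrogen). For the measured compounds named here, since the one earlier example of this change left no readable step, there is nothing to say how large the move from compound 3 to compound 4 will be, and the plain expectation is a modest step, a 1.6-fold higher number from compound 3 to compound 4 (0.20 log units; within the scatter), with wide uncertainty in both directions. On that basis compound 4 is estimated to give 20000 nM in this assay, with a plausible range from 4000 nM to 100000 nM.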

Compound 4, half-maximal inhibitory concentration: > 128000 nM
Compound 4 ended at the assay's limit; the forecaster's own chance of this, stated with the estimate: 25%; middle value at least 6.4-fold (0.80 log units) from the limit.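

In this assay, replacing tert-butoxycarbonyl with benzyloxycarbonyl on the core that carries the 2-chlorophenyl group gave an at least 10-fold higher number from compound 3 to compound 4 (1.01 log units; beyond the scatter), so on this core the benzyl group leaves a clearly weaker inhibitor. Going by these compounds, compound 4 gives > 128000 nM, which is a limit and not a number, so the true size of this step remains unknown. The compounds do not show whether the change carries over from one core to another, neither that it does nor that it fails to, because the same change on the core with the 3,4-dichlorophenyl group and the step between the two benzyloxycarbonyl compounds both cannot be read: the limit of > 128000 nM in this assay, at which 3 of the 4 values shown sit.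

For the compounds shown here, compound 3 gives 12500 nM, the only true number in the set, so all that can be read here rests on a single compound with tert-butyl and 2-chlorophenyl together. What the compounds shown leave open is whether anything on this side of the core can improve on that number, for example an ethyl group in place of tert-butyl or a free amine in place of the whole tert-butoxycarbonyl group, and whether an unsubstituted phenyl would behave like the 2-chlorophenyl group.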